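Debenzylation on two related cores: series notes

The compounds below may be only part of what the source reports. "The series", "measured", "known", "first", "only" and "open" are said of these compounds alone.

Compound 1 `COc1cc(OC)c2cc(-c3ccc(OCc4ccccc4)cc3)c(O)nc2c1` is measured in a functional assay on J82 cells (Homo sapiens) for cytotoxicity, read by colorimetric assay and MTT assay; on this read-out lower numbers stand for stronger inhibition and higher numbers for weaker inhibition; compound 1 gives 10000 nM. Compound 2 `COc1ccc(-c2cc3c(OC)cc(OC)cc3n(CC(=O)OCc3ccccc3)c2=O)cc1` gives 10000 nM in this assay, and compound 3 `COc1ccc(-c2cc3c(OC)cc(OC)cc3n(CC(=O)O)c2=O)cc1` gives 10000 nM. The difference between the core of compound 1 and the core of compound 2 is not broken down here. From compound 2 to compound 3 the change is hydrogen in place of benzyl on an oxygen next to a carbonyl group, and it made no change at the digits printed from compound 2 to compound 3 (within the scatter).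

Compound 4 `COc1cc(OC)c2cc(-c3ccc(O)cc3)c(O)nc2c1` is not yet measured. It differs from compound 1 by hydrogen in place of benzyl on an oxygen on an aromatic ring. This is the same kind of change as from compound 2 to compound 3, not the same: there the oxygen sits next to a carbonyl group, here on an aromatic ring. Given no change at the digits printed from compound 2 to compound 3 (within the scatter), the step from compound 1 to compound 4 is expected to be no change at the digits printed from compound 1 to compound 4 (within the scatter). Compound 4 is thus estimated at 10000 nM in this assay, between 5000 nM and 20000 nM.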

Compound 4, half-maximal inhibitory concentration: 10000 nM
For compound 4 middle estimate and measured number coincide at the digits printed, and the stated range covers the measured number.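

In this assay the change on the core of compound 1 reads no change at the digits printed from compound 1 to compound 4 (within the scatter), and set beside the earlier step on the other core the two agree: the same change on two cores in this assay, no change at the digits printed (within the scatter) from compound 2 to compound 3 and no change at the digits printed (within the scatter) from compound 1 to compound 4, 1.0-fold (0.00 log units) apart, within the scatter of two such steps.
The agreement rests on two cores only, with the oxygen on an aromatic ring in one and next to a carbonyl group in the other. Neither step moves the read-out, so the pair shows that the absence of a change carries across these two cores, not that a step of measurable size would carry over or that the same would hold on a further core.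

As far as these compounds go, whether a longer chain in place of benzyl on that oxygen, or an amine or a carboxylic acid in place of benzyloxy, would shift the value from that of compound 4, 10000 nM, stays open.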